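The source may report more compounds than this note shows. Statements on the series, on what has been measured and on what is new or still open speak of the compounds shown alone.

Working notes on the series. The shared core of compound 1 `N#Cc1ccc(/C=N/Nc2nc(N)c3ncn([C@@H]4O[C@H](CO)[C@@H](O)[C@H]4O)c3n2)cc1` is kept throughout, and the group on the carbon with a double bond to nitrogen is varied. In an assay on CHO-K1 cells for displacement of a labelled ligand from adenosine receptor A1 (Homo sapiens), read by scintillation counting, with a stated time of 60 min (on this read-out lower numbers stand for stronger inhibition and higher numbers for weaker inhibition), compound 1 gives 4.1 nM. Compound 2 `Nc1nc(N/N=C/c2ccc3ncccc3c2)nc2c1ncn2[C@@H]1O[C@H](CO)[C@@H](O)[C@H]1O` gives 9.8 nM in this assay. Compound 3 `CCCCc1nc(/C=N/Nc2nc(N)c3ncn([C@@H]4O[C@H](CO)[C@@H](O)[C@H]4O)c3n2)c(Cl)[nH]1` gives 12 nM in this assay, the highest of the three numbers: a 1.2-fold higher number from compound 2 to compound 3 (0.09 log units; within the scatter) lies within the scatter, whereas a 2.9-fold higher number from compound 1 to compound 3 (0.47 log units; beyond the scatter) lies beyond it, as does a 2.4-fold higher number from compound 1 to compound 2 (0.38 log units; beyond the scatter).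

Compound 4 `Nc1nc(N/N=C/c2ccc[nH]2)nc2c1ncn2[C@@H]1O[C@H](CO)[C@@H](O)[C@H]1O` is not yet measured. Its change from compound 3: 1H-pyrrol-2-yl in place of 2-butyl-5-chloro-1H-imidazol-4-yl on a carbon with a double bond to nitrogen. All three measured steps are exchanges of the group on this same carbon, and none went beyond a modest size; the exchange between compound 2 and compound 3 stayed within the scatter. Going by the values given here, no measured compound carries 1H-pyrrol-2-yl, so the expectation rests only on the range of those exchanges. For compound 4 a small step in this assay is expected, if any, most likely toward a somewhat higher number, and the estimated step is a 1.7-fold higher number from compound 3 to compound 4 (0.22 log units; within the scatter). The estimate for compound 4 in this assay is 20 nM, with a range from 6 nM to 70 nM.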

Compound 4, inhibition constant: 8 nM
Estimate against measurement, compound 4: 2.5-fold (0.40 log units) above; the range from low to high includes it.
By their numbers in this assay, from the lowest: compounds 1, 4, 2 and 3 (each within the scatter of the next, the first and the last beyond it).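

In this assay, 1H-pyrrol-2-yl on the carbon with a double bond to nitrogen replaces 2-butyl-5-chloro-1H-imidazol-4-yl, and with it the butyl chain and the chlorine, with a 1.5-fold lower number from compound 3 to compound 4 (0.18 log units; within the scatter); it replaces quinolin-6-yl with a 1.2-fold lower number from compound 2 to compound 4 (0.09 log units; within the scatter), and both steps lie within the scatter. Against 4-cyanophenyl the result is a 2.0-fold higher number from compound 1 to compound 4 (0.29 log units; within the scatter), also within the scatter, so compound 4 stands apart from none of the other three, although compound 1 and compound 3 remain separated beyond the scatter. No measured evidence accounts for these steps.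

All four groups shown at this carbon are aromatic rings, so it remains open whether a saturated group such as cyclohexyl, or a carboxylic acid or an amine carried on the ring, would stay in this narrow range. Also open, going by these compounds, is whether a furan-2-yl group, with oxygen in the ring in place of the nitrogen of 1H-pyrrol-2-yl, would keep the number of compound 4.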